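Aryl amide variation on the shared core: working notes

This account rests on a few compounds, and the source may have more. Where it says the series, first, only, none or still open, it means among the compounds named here.

Measured compounds:
compound 1 `Cc1cccc(NC(=O)COc2ccc(/C=C3\SC(=O)NC3=O)cc2)n1`: 75000 nM
compound 2 `O=C(COc1ccc(/C=C2\SC(=O)NC2=O)cc1)Nc1ccc(F)cc1F`: > 100000 nM (a limit of the assay, not a number)
compound 3 `Cc1ccc(NC(=O)COc2ccc(/C=C3\SC(=O)NC3=O)cc2)cc1Cl`: 99600 nM

In a functional assay on KB cells (Homo sapiens) for inhibition (a lower number here means a stronger inhibitor of growth, a higher number a weaker inhibitor of growth), compound 1 stands lowest of the two numbers shown; the step of a 1.3-fold higher number from compound 1 to compound 3 (0.12 log units; within the scatter) lies within the scatter. The limit for compound 2 is recorded in the limit of > 100000 nM in this assay, at which 1 of the 3 values shown sits. Compound 4 `O=C(COc1ccc(/C=C2\SC(=O)NC2=O)cc1)Nc1c(F)cc(Br)cc1F` differs from compound 1 in that (4-bromo-2,6-difluorophenyl in place of 6-methylpyridin-2-yl on an amide-type nitrogen). Within the data shown here, the steps that bear on this change are an at least 1.3-fold higher number from compound 1 to compound 2 (0.12 log units; that floor lies within the scatter) and a 1.3-fold higher number from compound 1 to compound 3 (0.12 log units; within the scatter); both are small, and the former ends at a limit. No more than a modest rise in the number is therefore expected, and a limit is plausible. Compound 4 is expected to give 120000 nM, between 55000 nM and 260000 nM. For compound 4 this means an expected step of a 1.6-fold higher number from compound 1 to compound 4 (0.20 log units; within the scatter).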

Compound 4, concentration for 50% growth inhibition: > 100000 nM
Compound 4: no number, only a limit; the forecaster's own chance of this, stated with the estimate: 55%; the middle value lies beyond the limit too.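

In this assay, 4-bromo-2,6-difluorophenyl on the amide-type nitrogen gives an at least 1.3-fold higher number from compound 1 to compound 4 (0.12 log units; that floor lies within the scatter), so this change shows no sign of a lower number. Compound 4 gives a limit of the assay, not a number, and a second halogenated phenyl group now ends at that limit: the limit of > 100000 nM in this assay, at which 2 of the 4 values shown sit. In place of 3-chloro-4-methylphenyl, the same group gives a number no lower from compound 3 to compound 4 (the limit leaves the size open) as well. The step from compound 2 to compound 4 cannot be read.

On these data alone, how far compound 2 and compound 4 lie past the limit stays open. So does the effect of a carboxylic acid or an aliphatic amine in place of these aryl groups.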